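The compounds below may be only part of what the source reports. "The series", "measured", "known", "first", "only" and "open" are said of these compounds alone.

Measured compounds:
compound 1, `Nc1ccccc1NC(=O)c1ccc(CSC(=S)N2CCN(Cc3ccccn3)CC2)cc1`, 23.4%;
compound 2, `CCN(Cc1ccncc1)C(=S)SCc1ccc(C(=O)Nc2ccccc2N)cc1`, 71.6%;
compound 3, `CC1CCN(C(=S)SCc2ccc(C(=O)Nc3ccccc3N)cc2)CC1`, 28.1%.

In a functional assay on MGC-803 cells (Homo sapiens) for antiproliferative activity, read by CCK-8 assay, with a stated time of 72 h, tested at 2 uM (a lower number here means a weaker effect, a higher number a stronger effect of the compound at the concentration tested), compound 1 gives the lowest of the three numbers. Compound 3 sits nearest, with a value within the scatter of compound 1, so no order between the two can be claimed. Compound 2 lies well beyond the scatter of both. Going by the values given here, the only step within the measured set is the change a number 43.5 percentage points lower from compound 2 to compound 3 (beyond the scatter), a large fall; it concerns the group on the thiocarbonyl carbon and not the part of the molecule altered here.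

Compound 4, `Nc1ccccc1NC(=O)c1ccc(CSC(=S)N2CCN(c3cnccn3)CC2)cc1`, is not yet measured. It differs from compound 1 in one place: pyrazin-2-yl in place of (pyridin-2-yl)methyl on an amine nitrogen in a ring, on the amine nitrogen of the six-membered non-aromatic ring with two nitrogens. Among the compounds with values here, no measured step touches this position, so nothing in the data says how this assay responds to it. The nearest measured values, compounds 1 and 3, are both low, and compound 4 is therefore expected to stay in that region. The estimate for compound 4 is 30%, between 12% and 55%, which means an expected step of a number 6.6 percentage points higher from compound 1 to compound 4 (within the scatter) that need not exceed the scatter.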

Compound 4, a percentage reported as inhibition, at one concentration (the size of the read-out at that concentration, not a potency): 27.1%
For compound 4 the middle estimate is 2.9 percentage points above the measured one; low and high end bracket the measured number.
By their numbers in this assay, from the lowest: compounds 1, 4 and 3 (each within the scatter of the next); then compound 2.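

In this assay, going by these compounds alone, this is the first change seen on the amine nitrogen in a ring, and it gives a number 3.7 percentage points higher from compound 1 to compound 4 (within the scatter). Exchanging (pyridin-2-yl)methyl for pyrazin-2-yl therefore removes the methyl link and adds a second hetero atom to the aromatic ring, yet the combined change does not move the read-out beyond the scatter. No available measurement offers an explanation for this result.

Since the link and the ring change together, the compounds shown cannot separate their contributions or show whether the two effects offset each other; pyridin-2-yl or (pyrazin-2-yl)methyl on the same nitrogen would address this. As far as these compounds go, it also remains open how this assay would respond to a group without an aromatic ring at this position, such as acetyl or a 2-hydroxyethyl chain.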